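The compounds below may be only part of what the source reports. "The series", "measured", "known", "first", "only" and "open" are said of these compounds alone.

- compound 1 (`CC/C=C/C(=O)Nc1cccc(Oc2nc(Nc3cccc(C#N)c3)nc3c2CSCC3)c1`) gives 31800 nM
- compound 2 (`CC(C)=CC(=O)Nc1cccc(Oc2nc(Nc3cccc(C#N)c3)nc3c2CSCC3)c1`) gives 29200 nM
- compound 3 (`CC(C)/C=C/C(=O)Nc1cccc(Oc2nc(Nc3cccc(C#N)c3)nc3c2CSCC3)c1`) gives 22800 nM

In a functional assay on HeLa cells (Homo sapiens) for antiproliferative activity, read by MTT assay, with a stated time of 72 h (a lower number here means a stronger inhibitor, a higher number a weaker inhibitor), compound 1 cannot be told apart from the other two, since (a 1.1-fold lower number from compound 1 to compound 2 (0.04 log units; within the scatter)) and (a 1.4-fold lower number from compound 1 to compound 3 (0.14 log units; within the scatter)) both lie within the scatter, as does (a 1.3-fold lower number from compound 2 to compound 3 (0.11 log units; within the scatter)). Compound 4 (`CC/C=C/C(=O)Nc1cccc(Oc2nc(Nc3ccc(OC)cc3)nc3c2CSCC3)c1`) keeps the core of compound 1 but carries 4-methoxyphenyl in place of 3-cyanophenyl on a nitrogen on an aromatic ring. All three measured steps altered only the chain on the carbonyl carbon, so none of them tests this change. With no measured guide, no step beyond the scatter is expected in this assay and no direction is favoured. The expected step runs (a 1.3-fold lower number from compound 1 to compound 4 (0.10 log units; within the scatter)) and is only a rough guess. Compound 4 is estimated at 25000 nM with an expected range from 7000 nM to 70000 nM in this measurement.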

Compound 4, half-maximal inhibitory concentration: 27200 nM
Beside the measured number, compound 4's estimate is 1.1-fold (0.04 log units) below it, and the stated range covers the measured number.
By their numbers in this assay, from the lowest: compounds 3, 4, 2 and 1 (each within the scatter of the next).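

Within the data shown here, this is the first change away from the chain on the carbonyl carbon. In this assay, putting 4-methoxyphenyl in place of 3-cyanophenyl on the nitrogen gives a 1.2-fold lower number from compound 1 to compound 4 (0.07 log units; within the scatter), so this swap stays within the scatter, as the chain changes did. No supporting measurement bears on this result, so it offers no explanation. From the compounds shown here alone, it remains open whether a plain phenyl, or a phenyl carrying an amine or a carboxylic acid, would also stay within the scatter. Going by these compounds, it is also open whether 4-methoxyphenyl would behave alike alongside the chains of compound 2 and compound 3.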